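The source may hold more compounds than are shown below. What is called first, only, known or untested is meant among the compounds shown, and "the series" means these compounds.

Among the two compounds so far measured in a functional assay on the whole organism (blood, strain Wistar-Okamoto) with Rattus norvegicus as the target, with a stated time of 5 days (on this read-out lower numbers stand for an effect already at smaller amounts and higher numbers for an effect only at larger amounts of compound), compound 2 `CCC(C)(C)N/C(=N\C#N)NCc1ccncc1` stands highest: compound 2 gives 20 mg/kg, while compound 1 `CCC(CC)(CC)/N=C(\NC#N)Nc1cccnc1` gives 1 mg/kg, a gap beyond the usual scatter. Compound 3 `CC(N/C(=N\C#N)NCc1ccncc1)C(C)(C)C` differs from compound 2 in a single place: 1,2,2-trimethylpropyl in place of 1,1-dimethylpropyl on an amine nitrogen. Among the measured compounds shown here, no measured pair shows this particular change, so its effect is not yet known. Both the group that leaves and the group that enters are branched alkyl groups without a ring, and the expected step from compound 2 to compound 3 in this assay is no change at the digits printed from compound 2 to compound 3 (within the scatter), nothing beyond the scatter. In this assay compound 3 is therefore estimated at 20 mg/kg, with a range from 8 mg/kg to 50 mg/kg.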

Compound 3, minimum effective dose: 20 mg/kg
Estimate against measurement, compound 3: no gap at the digits printed; measured number inside the range.
By their numbers in this assay, from the lowest: compound 1; then compounds 2 and 3 (each within the scatter of the next).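

In this assay, the amine nitrogen accepts 1,2,2-trimethylpropyl in place of 1,1-dimethylpropyl with no change at the digits printed from compound 2 to compound 3 (within the scatter). Among the compounds shown here, this is the first reading at this position, and the read-out does not tell these two branched alkyl groups without a ring apart. Nothing available explains this result. The compounds shown leave open whether a straight hexyl chain, a cyclohexyl group or a chain carrying an amine at this place would read the same. They also do not show how far this position tolerates change beyond branched alkyl groups.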